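Predicting cytotoxicity of a chloro-substituted analogue

The compounds below may be only part of what the source reports. "The series", "measured", "known", "first", "only" and "open" are said of these compounds alone.

Measured compounds:
compound 1 `O=C1/C(=C\c2ccccc2)S/C(=N/c2ccccc2)N1Cc1ccncc1`: 64700 nM
compound 2 `O=C1/C(=C\c2ccc(O)cc2)S/C(=N/c2ccccc2)N1Cc1ccncc1`: 142000 nM
compound 3 `COc1cc(/C=C2/S/C(=N/c3ccccc3)N(Cc3ccncc3)C2=O)ccc1O`: 67400 nM

These three compounds share one core and were all tested in an ADME assay on HEK293 cells (Homo sapiens) for cytotoxicity, read by MTT assay, with a stated time of 48 h; on this read-out lower numbers stand for stronger inhibition and higher numbers for weaker inhibition. Compound 2 gives the highest of the three numbers, so it is the least cytotoxic here: the nearest is compound 3 a 2.1-fold lower number from compound 2 to compound 3 (0.32 log units; beyond the scatter) and the furthest is compound 1 a 2.2-fold higher number from compound 1 to compound 2 (0.34 log units; beyond the scatter). The new compound 4 `O=C1/C(=C\c2cccc(Cl)c2)S/C(=N/c2ccccc2)N1Cc1ccncc1` has not yet been measured. Relative to compound 2 it carries 3-chlorophenyl in place of 4-hydroxyphenyl on a double-bonded chain carbon bound to a double-bonded ring carbon. The step that bears most directly on this is the one that added the hydroxy group a 2.2-fold higher number from compound 1 to compound 2 (0.34 log units; beyond the scatter), a modest change beyond the scatter; removing that group should roughly undo it, pointing back toward the number of compound 1. For the measured compounds named here, no measured step tells what the chlorine itself does, so the estimate is correspondingly uncertain. Compound 4 is therefore expected to give a 2.4-fold lower number from compound 2 to compound 4 (0.37 log units; beyond the scatter), landing near 60000 nM with a likely range from 25000 nM to 140000 nM.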

Compound 4, half-maximal inhibitory concentration: 71800 nM
For compound 4 the middle estimate is 1.2-fold (0.08 log units) below the measured one; the range from low to high includes it.
By their numbers in this assay, from the lowest: compounds 1, 3, 4 and 2 (each within the scatter of the next, the first and the last beyond it).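

In this assay, the added chlorine gives a 1.1-fold higher number from compound 1 to compound 4 (0.05 log units; within the scatter), so this first measured change that adds no hydroxy group leaves compound 4 indistinguishable from compound 1. The 3-chlorophenyl group also cannot be told apart from the two hydroxy-bearing groups, with a 1.1-fold higher number from compound 3 to compound 4 (0.03 log units; within the scatter) and a 2.0-fold lower number from compound 2 to compound 4 (0.30 log units; within the scatter), so compound 4 stands within the scatter of all three earlier compounds. No measurement shown here accounts for these results.

The compounds shown leave open whether an amine or a carboxylic acid on this aromatic ring would give a number beyond the scatter of compound 1. They also leave open what a longer chain would do at this place, on a double-bonded chain carbon bound to a double-bonded ring carbon.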